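This account rests on a few compounds, and the source may have more. Where it says the series, first, only, none or still open, it means among the compounds named here.

Measured so far in a functional assay on HepG2 cells (Homo sapiens) for antiproliferative activity, read by MTT assay, with a stated time of 72 h (on this read-out higher numbers stand for weaker inhibition and lower numbers for stronger inhibition), as follows
- compound 1 `O=C(N/N=C/c1ccc([N+](=O)[O-])cc1)Nc1ccc(Oc2ccnc3[nH]ccc23)c(F)c1` gives 3030 nM
- compound 2 `COc1ccc(/C=N/NC(=O)Nc2ccc(Oc3ccnc4[nH]ccc34)c(F)c2)c(OC)c1OC` gives 2990 nM

For the measured compounds named here, compound 1 and compound 2 stand level within the scatter, so compound 1 sits with the only other measured compound. Compound 3 `O=C(N/N=C/c1cc(Br)c(O)c(Br)c1)Nc1ccc(Oc2ccnc3[nH]ccc23)c(F)c1` has 3,5-dibromo-4-hydroxyphenyl in place of 4-nitrophenyl on a carbon with a double bond to nitrogen and is still unmeasured. Going by the values given here, no measured step exists to guide this change in this assay, so no shift beyond the scatter is expected. The expected change is a 1.2-fold lower number from compound 1 to compound 3 (0.07 log units; within the scatter) and the range stays wide. For compound 3 the estimated value is 2600 nM with an expected range from 900 nM to 7500 nM on this read-out.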

Compound 3, half-maximal inhibitory concentration: 6520 nM
Compound 3: the middle estimate sits 2.5-fold (0.40 log units) below what was measured; measured number inside the range.
By their numbers in this assay, from the lowest: compounds 2 and 1 (each within the scatter of the next); then compound 3.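

In this assay, 3,5-dibromo-4-hydroxyphenyl in place of 4-nitrophenyl on a carbon with a double bond to nitrogen gives a 2.2-fold higher number from compound 1 to compound 3 (0.33 log units; beyond the scatter). For the compounds shown here, this is the first step beyond the scatter: the aryl group at this position can weaken inhibition, though only modestly. No available evidence accounts for the shift.

On these data alone, the hydroxyl and the two bromines enter together, so their separate contributions remain open. Also open, as far as these compounds go, is how a simple phenyl, a pyridine ring or a carboxylic acid would behave at this position.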